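Adding a Phenyl to the Sigma-1 Ligand Compound 2

A few compounds are considered here, and "the series" means these few. Any claim that something is new, unique, unknown or untested is made for them only; others in the source may bear on it.

Within the data shown here, compound 2 `COC1Cc2cscc2C2(CCN(Cc3ccccc3)CC2)O1` gives 0.22 nM in an assay on membranes from brain for displacement of a labelled ligand from Sigma non-opioid intracellular receptor 1 (Cavia porcellus), read by scintillation counting, with a stated time of 120 min (on this read-out higher numbers stand for weaker inhibition and lower numbers for stronger inhibition), the lowest of the two numbers measured so far. Compound 1 `c1ccc(CN2CCC3(CC2)OCCc2c3csc2-c2ccccc2)cc1`, which also carries a phenyl on its core, gives 4.5 nM in this assay, a weaker result. Compound 3 `COC1Cc2c(csc2-c2ccccc2)C2(CCN(Cc3ccccc3)CC2)O1` is compound 2 with one change: phenyl in place of hydrogen on an aromatic carbon. Because compound 1 gives 4.5 nM with a phenyl present, a shift toward weaker inhibition is expected, likely beyond the scatter, as the step of a 6.8-fold higher number from compound 2 to compound 3 (0.83 log units; beyond the scatter). Compound 3 is therefore estimated at 1.5 nM, with a range from 0.3 nM to 8 nM.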

Compound 3, inhibition constant: 1 nM
The estimate for compound 3 lay 1.5-fold (0.18 log units) above the measured number, and the stated range covers the measured number.
By their numbers in this assay, from the lowest: compound 2; then compound 3; then compound 1.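

On this aromatic carbon next to the ring sulfur, phenyl in place of hydrogen weakens inhibition only modestly (a 4.5-fold higher number from compound 2 to compound 3 (0.66 log units; beyond the scatter)), so the position accepts this ring at a measurable cost. With that phenyl present, methoxy on the saturated ring carbon still strengthens inhibition (a 4.5-fold lower number from compound 1 to compound 3 (0.65 log units; beyond the scatter)), a shift opposite in direction to the first. No supporting evidence bears on the reason for either shift. Going by these compounds, whether methyl, chlorine or an amine at the same aromatic carbon would cost less remains open. So does the effect of methoxy when the phenyl is absent.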